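A few compounds are considered here, and "the series" means these few. Any claim that something is new, unique, unknown or untested is made for them only; others in the source may bear on it.

Measured compounds:
- compound 1, `CCCN(Cc1ccc(OCCN2C(=O)CCC2=O)c(C)c1)C(CC(=O)O)c1ccc(Cl)cc1`: 75%
- compound 2, `CCCN(Cc1ccc(OCCN2C(=O)CCC2=O)c(C)c1)[C@@H](CC(=O)O)c1ccc(Cl)cc1`: 97%

The read-out throughout is an ADME assay on liver (Mus musculus) for metabolic stability, read by LC-MS, using microsomes and NADPH; on this read-out lower numbers stand for a less stable compound and higher numbers for a more stable compound. For the measured compounds named here, on these two numbers compound 1 stands lowest; its only neighbour is compound 2, and the step of a number 22 percentage points higher from compound 1 to compound 2 (beyond the scatter) is a modest rise. The two compounds share every atom and bond, and the only point of difference is the fact that one of compounds 1 and 2 is drawn with a defined configuration and the other without, at the place where they differ, so this step says nothing about how a change of substituent would move the read-out.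

The compound at issue is compound 3, `CCCN(Cc1ccc(OCCn2c(=O)ccn(C)c2=O)c(C)c1)C(CC(=O)O)c1ccc(Cl)cc1`. It is derived from compound 1 by the change (a group of 9 heavy atoms (5 carbon, 2 nitrogen, 2 oxygen; one six-membered aromatic ring with 2 hetero atoms) in place of a group of 7 heavy atoms (4 carbon, 1 nitrogen, 2 oxygen; one five-membered non-aromatic ring with 1 hetero atom), on a saturated chain carbon, two bonds along the chain from an oxygen on an aromatic ring). Going by the values given here, no measured pair shows a replacement of the 2,5-dioxopyrrolidin-1-yl group or any other exchange of substituents, so there is no measured step that bears on this change. Without such a precedent, the expectation for compound 3 is a step of a number 3 percentage points lower from compound 1 to compound 3 (within the scatter), that is, no movement beyond the scatter from compound 1. Compound 3 is therefore estimated at 72%, with a range from 45% to 95%.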

Compound 3, percent of the compound remaining: 23%
Estimate against measurement, compound 3: 49 percentage points above, and the stated range ends above it.
By their numbers in this assay, from the lowest: compound 3; then compound 1; then compound 2.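

In this assay, the saturated chain carbon two bonds along the chain from an oxygen on an aromatic ring proves to be a place where the group matters: putting the six-membered aromatic ring with 2 hetero atoms in place of 2,5-dioxopyrrolidin-1-yl gives a number 52 percentage points lower from compound 1 to compound 3 (beyond the scatter), a large step. For the compounds shown here, the only earlier step concerned how one stereocentre was drawn, so this is the first sign that an exchange of substituent at this place can move the read-out, and it moves it downward, well beyond the scatter. Nothing among the measurements given bears on why this exchange lowers the read-out.

The compounds shown leave open whether the fall goes with the aromatic character of the entering ring, with its six-membered size or with its methyl group, and whether a piperidine-2,6-dione or an open-chain acetamide at this place would stay nearer to compound 1. They also leave open whether drawing the stereocentre of compound 3 as S would raise its number in the way seen on going from compound 1 to compound 2.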